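The compounds below may be only part of what the source reports. "The series", "measured", "known", "first", "only" and "open" are said of these compounds alone.

Measured compounds:

Compound 1, `COc1ccc(C2N=C(SCc3ccccc3Cl)NC(C)=C2C(=O)Nc2ccc(F)cc2)cc1OC`, in a functional assay on the whole organism (artery, strain albino) with Rattus norvegicus as the target, with a stated time of 300 min, at a dose of 10 mg/kg by the oral route (a lower number here means less inhibition, a higher number more inhibition at the dose given (going by the name of the read-out)), gives 35.9%.
Compound 2, `COc1ccc(C2N=C(SCc3cccc(Cl)c3)NC(C)=C2C(=O)Nc2ccc(F)cc2)cc1OC`, in this assay gives 16.4%.
Compound 3, `CC1=C(C(=O)Nc2ccc([N+](=O)[O-])cc2)C(c2cccc([N+](=O)[O-])c2)N=C(SCc2ccccc2Cl)N1`, in this assay gives 15.9%.

For the measured compounds named here, the three compounds share a core, and the single counted change among them is 3-chlorophenyl in place of 2-chlorophenyl on a saturated chain carbon bound to a sulfur. That change occurs two times among the compounds shown: once between compound 1 and compound 2, and once between compound 3 and the unmeasured compound 4, `CC1=C(C(=O)Nc2ccc([N+](=O)[O-])cc2)C(c2cccc([N+](=O)[O-])c2)N=C(SCc2cccc(Cl)c2)N1`, where it reads (3-chlorophenyl in place of 2-chlorophenyl on a saturated chain carbon bound to a sulfur). The two place lines are identical word for word, so this is the same change, not merely the same kind. How the core of compound 3 differs from the core of compound 1 is not broken down here.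

In this assay, going by the values given here, the first occurrence made a step of a number 19.5 percentage points lower from compound 1 to compound 2 (beyond the scatter), a modest drop that lies beyond the scatter. Compound 3 sits at the lowest of the three numbers; its value and that of compound 2 are within the scatter of each other, while compound 1 lies beyond the scatter above it.

For compound 4 the expectation rests on a single observed step. The estimated step is a number 8.9 percentage points lower from compound 3 to compound 4 (within the scatter), expected to follow the direction of a number 19.5 percentage points lower from compound 1 to compound 2 (beyond the scatter) but from a lower starting point, where the read-out leaves little room to fall. Compound 4 is therefore estimated at 7%, with a range from -6% to 20%.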

Compound 4, a percentage reported as inhibition, in the whole organism at one dose (the size of the read-out at that dose, not a potency): 21%
For compound 4 the middle estimate is 14 percentage points below the measured one, outside the stated range (above it).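

In this assay, the exchange of 2-chlorophenyl for 3-chlorophenyl on the core of compound 3 gave a number 5.1 percentage points higher from compound 3 to compound 4 (within the scatter), so the clear drop seen on the core of compound 1 did not reappear, and the two results disagree: the same change on two cores in this assay, a number 19.5 percentage points lower (beyond the scatter) from compound 1 to compound 2 and a number 5.1 percentage points higher (within the scatter) from compound 3 to compound 4, 24.6 percentage points apart, beyond the scatter of two such steps. This shows that, among these two pairs, the result of this change on one core did not carry over to the other, so a step read on one core gives no safe estimate for the other. It does not show what sets the two cores apart in this respect, since they differ in more than one place and those differences are not taken apart here, nor does it give a general rule for the series, since it rests on a single pair per core, each read at one oral dose and one stated time.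

Open, as far as these compounds go, is whether the change would follow the step on the core of compound 1 or that on the core of compound 3 if it were carried to a third core, one that differs from either by a single group. Also open, from the compounds shown here alone, is how a longer chain in place of the benzyl on the sulfur, or an amine or a carboxylic acid in place of the chlorine, would read out in this assay.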